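This account rests on a few compounds, and the source may have more. Where it says the series, first, only, none or still open, it means among the compounds named here.

The measured compounds:
Compound 1, `Cc1cc(C#N)cc(C)c1Oc1nc(Nc2ccc(C#N)cc2)ncc1-c1cccs1`, gives 6430 nM in an ADME assay on MT4 cells (Homo sapiens) for cytotoxicity, read by MTT assay, with a stated time of 5 days; a lower number here means that less compound is tolerated, a higher number that more compound is tolerated.
Compound 2, `Cc1cc(C#N)cc(C)c1Oc1nc(Nc2ccc(C#N)cc2)ncc1-c1ccc(N)cc1`, gives 310 nM in this assay.
Compound 3, `Cc1cc(C#N)cc(C)c1Oc1nc(Nc2ccc(C#N)cc2)ncc1-c1cccnc1`, gives 13500 nM in this assay.

Among these three, compound 1 stands second highest in this assay: the step of a 2.1-fold higher number from compound 1 to compound 3 (0.32 log units; beyond the scatter) is modest, while the step of a 21-fold lower number from compound 1 to compound 2 (1.32 log units; beyond the scatter) is large. Compound 4, `Cc1cc(C#N)cc(C)c1Oc1nc(Nc2ccc(C#N)cc2)ncc1-c1ccccc1`, differs from compound 1 in one place: phenyl in place of thiophen-2-yl on an aromatic carbon. Two measured steps start from compound 1 and exchange the same group. The exchange for 4-aminophenyl, a 21-fold lower number from compound 1 to compound 2 (1.32 log units; beyond the scatter), moved the number a long way downward; the exchange for pyridin-3-yl, a 2.1-fold higher number from compound 1 to compound 3 (0.32 log units; beyond the scatter), moved it only modestly upward. Among the measured compounds shown here, neither of those groups is phenyl, so the measured steps give no direct guide, and nothing among the measured compounds points to a large shift for a ring of carbon only. For compound 4 a step within or only just beyond the scatter is expected, in either direction. The expected step is a 1.3-fold lower number from compound 1 to compound 4 (0.11 log units; within the scatter). Compound 4 is therefore estimated at 5000 nM in this assay, with a range from 1500 nM to 16000 nM.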

Compound 4, half-maximal cytotoxic concentration: 31800 nM
Compound 4: the middle estimate sits 6.4-fold (0.80 log units) below what was measured; measured number above the stated range.
By their numbers in this assay, from the lowest: compound 2; then compound 1; then compound 3; then compound 4.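

In this assay, the plain phenyl ring gives the highest number of the four groups at this position, with a 4.9-fold higher number from compound 1 to compound 4 (0.69 log units; beyond the scatter) and a 2.4-fold higher number from compound 3 to compound 4 (0.37 log units; beyond the scatter) showing that more compound is tolerated than with either ring carrying a hetero atom. Compound 2 goes against any simple rule that a ring of carbon only is well tolerated: removing its amino group gives a 100-fold higher number from compound 2 to compound 4 (2.01 log units; beyond the scatter), so the low number of compound 2 goes with that amino group and not with the six-membered ring that carries it. The measurements show how far the number moves with each change, but nothing here gives a reason for these steps.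

From the compounds shown here alone, it remains open whether a hydroxyl, a methoxy or a methyl group in place of the amino group on the phenyl ring would lower the number as well, or whether the drop is particular to the amine. Also open, going by these compounds, is how a ring that is not aromatic, such as cyclohexyl, or a short chain such as ethyl would behave on this aromatic carbon.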